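From Dibromophenyl to Methoxymethylphenyl at the Ring Nitrogen

A few compounds are considered here, and "the series" means these few. Any claim that something is new, unique, unknown or untested is made for them only; others in the source may bear on it.

Measured compounds:
compound 1, `CCCCN(CC)c1cc(C)nc2c1NC(=O)CN2c1ccc(C(C)C)cc1Br`: 2.4 nM
compound 2, `CCCCN(CC)c1cc(C)nc2c1NC(=O)CN2c1ccc(Br)cc1Br`: 1.3 nM

Two compounds share one core and differ only in the aryl group on the ring nitrogen. In an assay on HEK-293T cells for displacement of a labelled ligand from corticotropin-releasing factor receptor 1 (Homo sapiens), read by scintillation counting, with a stated time of 2 h (on this read-out lower numbers stand for stronger inhibition and higher numbers for weaker inhibition), compound 1 gives 2.4 nM, and compound 2 gives 1.3 nM. For the measured compounds named here, the single measured step, a 1.8-fold lower number from compound 1 to compound 2 (0.27 log units; within the scatter), is bromo in place of isopropyl on an aromatic carbon; it lies within the scatter, so compound 2 and compound 1 cannot be told apart on these numbers, and compound 2 is simply one of two closely placed values.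

Compound 3, `CCCCN(CC)c1cc(C)nc2c1NC(=O)CN2c1ccc(OC)cc1C`, has not yet been measured. It carries 4-methoxy-2-methylphenyl in place of 2,4-dibromophenyl on a nitrogen on an aromatic ring in a ring. Going by the values given here, no measured step addresses this exact change, but the one step available bears on the same aryl group and shows tolerance there: a small change is expected for a 3.1-fold higher number from compound 2 to compound 3 (0.49 log units; beyond the scatter) because a 1.8-fold lower number from compound 1 to compound 2 (0.27 log units; within the scatter) stays within the scatter. Both substituents are now replaced at once, so some weakening is allowed for. Compound 3 is therefore estimated at 4 nM in this assay, within a range of 1 nM to 15 nM.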

Compound 3, inhibition constant: 4 nM
For compound 3 middle estimate and measured number coincide at the digits printed, and the stated range covers the measured number.
By their numbers in this assay, from the lowest: compounds 2, 1 and 3 (each within the scatter of the next, the first and the last beyond it).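

For the compounds shown here, the replacement of the whole 2,4-dibromophenyl group by 4-methoxy-2-methylphenyl on the ring nitrogen gives a 3.1-fold higher number from compound 2 to compound 3 (0.49 log units; beyond the scatter), the first step at this position that leaves the scatter in this assay, where the earlier pair could not be told apart. It also shows that this position does not need bromine for a measurable result: the entering group carries none, brings one oxygen and one hydrogen-bond acceptor by the count of its atoms, and compound 3 still gives 4 nM. The step is modest, and it records two substituent changes taken together, so it cannot be divided between them, nor do the data shown give any measured basis for explaining it.

The compounds shown leave open how much of the step belongs to the methoxy group and how much to the methyl group, as none of them makes either replacement alone on this aryl group. They also leave open how this read-out would respond to a basic amine such as dimethylamino, or to a carboxylic acid, on the same aryl group.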